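Aryl change on the ring nitrogen, compound 2 to compound 3

The source may hold more compounds than are shown below. What is called first, only, known or untested is meant among the compounds shown, and "the series" means these compounds.

Measured so far:
compound 1 `N#CC1=C(N)Oc2c(c3nc4ccccc4nc3c3ccccc23)C12C(=O)N(Cc1cnnn1-c1ccc(Cl)cc1)c1ccccc12` — > 50000 nM
compound 2 `CCOc1ccc(-n2nncc2CN2C(=O)C3(C(C#N)=C(N)Oc4c(N)cc5nc6ccccc6nc5c43)c3ccccc32)cc1` — 26800 nM

In a functional assay on MCF7 cells (Homo sapiens) for antiproliferative activity, read by MTT assay, with a stated time of 48 h (a higher number here means a weaker inhibitor, a lower number a stronger inhibitor), compound 1 gives > 50000 nM, which is a limit of the assay and not a number; compound 1 sits at the limit of > 50000 nM in this assay, at which 1 of the 2 values shown sits. In this assay, within the data shown here, compound 2 gives 26800 nM, the only number in the set, so compound 2 has no measured neighbour to rank against.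

Compound 3 `Cc1ccc(Cl)cc1-n1nncc1CN1C(=O)C2(C(C#N)=C(N)Oc3c(N)cc4nc5ccccc5nc4c32)c2ccccc21` differs from compound 2 in one place: 5-chloro-2-methylphenyl in place of 4-ethoxyphenyl on an aromatic nitrogen. Among the measured compounds shown here, no measured step of this kind exists in the set. The step of a 1.3-fold higher number from compound 2 to compound 3 (0.12 log units; within the scatter) is expected to be modest, close to the scatter, toward weaker inhibition if any. Compound 3 is estimated at 35000 nM, range 12000 nM to 100000 nM.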

Compound 3, half-maximal inhibitory concentration: 43500 nM
The estimate for compound 3 lay 1.2-fold (0.09 log units) below the measured number, and the stated range covers the measured number.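

In this assay, 5-chloro-2-methylphenyl in place of 4-ethoxyphenyl on the aromatic nitrogen gives a 1.6-fold higher number from compound 2 to compound 3 (0.21 log units; within the scatter). Among these compounds, this is the first readable step, and it does not separate the two aryl groups, although they differ in their substituents and in the hydrogen-bond acceptor count. No measurement shown bears on a cause for this result.

From the compounds shown here alone, whether an aryl group carrying an amine or a carboxylic acid would give a step beyond the scatter remains open. Going by these compounds, the role of the shared core also stays open, since compound 1 differs from compound 2 in more than one place.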